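A few compounds are considered here, and "the series" means these few. Any claim that something is new, unique, unknown or untested is made for them only; others in the source may bear on it.

Measured compounds:
- compound 1, `Nc1cc(N)c2nc(-c3ccccc3)c(Oc3ccc(Cl)c(Cl)c3)nc2c1`: < 100000 nM
- compound 2, `CCOC(=O)[C@H](CCC(=O)O)NC(=O)c1ccc(Sc2nc3cc(N)cc(N)c3nc2-c2ccccc2)cc1`: < 100000 nM
- compound 3, `CCOC(=O)[C@H](CCC(=O)O)NC(=O)c1ccc(Oc2nc3cc(N)cc(N)c3nc2-c2ccccc2)cc1`: < 50200 nM

All three compounds share a core that carries two amino groups and a phenyl group, and they were tested in a functional assay on UO-31 cells (Homo sapiens) for inhibition, read by sulforhodamine B assay, with a stated time of 48 h; on this read-out higher numbers stand for lower toxicity in this test and lower numbers for higher toxicity in this test. Compound 1 gave only a limit of the test, < 100000 nM, not a number. Compound 2 likewise gave only a limit, < 100000 nM. Compound 3 also gave only a limit, < 50200 nM. Two of the three values sit at the limit of < 100000 nM in this assay, at which 2 of the 3 values shown sit, and one at the limit of < 50200 nM in this assay, at which 1 of the 3 values shown sits, so none of them can be placed against another, and compound 1 cannot be ranked among them.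

Compound 4, `Nc1cc(N)c2nc(-c3ccccc3)c(Sc3ccc(F)cc3)nc2c1`, has not yet been tested in this assay. It differs from compound 1 in one place: (4-fluorophenyl)sulfanyl in place of 3,4-dichlorophenoxy on an aromatic carbon. Among the measured compounds shown here, since every measured value is only a limit, there is no measured step to lean on, and the expectation for this change is no step beyond the scatter. Compound 4 is therefore estimated at 50000 nM, with a range from 10000 nM to 100000 nM, which means an expected step that the limit leaves unreadable from compound 1 to compound 4.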

Compound 4, concentration lethal to 50% of the cells: < 100000 nM
Compound 4 ended at the assay's limit; the forecaster's own chance of this, stated with the estimate: 60%; the middle value is on the limit's open side.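

In this assay, among the compounds shown here, compound 1 and compound 4 each give only a limit of the test, not a number, and no step between them can be read. As far as these compounds go, whether (4-fluorophenyl)sulfanyl in place of 3,4-dichlorophenoxy changes the result at all, and in which direction, stays open.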